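From 2-chlorophenyl to naphthalen-2-yl on the amide-type nitrogen

The source may hold more compounds than are shown below. What is called first, only, known or untested is meant among the compounds shown, and "the series" means these compounds.

The measured compounds in a functional assay on MDA-MB-231 cells (Homo sapiens) for antiproliferative activity, read by MTT assay, with a stated time of 24 h (on this read-out higher numbers stand for weaker inhibition and lower numbers for stronger inhibition), read as follows:
Compound 1 `O=C([C@H]1Cc2ccccc2N1)N1CCN(c2nccc(Oc3cc(Cl)cc(Cl)c3)n2)CC1` gives > 50000 nM as a limit of the assay
Compound 2 `Cc1ccc(NC(=O)N2CCN(c3nccc(Oc4cc(Cl)cc(Cl)c4)n3)CC2)cc1` gives 11600 nM as a number
Compound 3 `O=C(Nc1ccccc1Cl)N1CCN(c2nccc(Oc3cc(Cl)cc(Cl)c3)n2)CC1` gives 11000 nM as a number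

For the measured compounds named here, compound 3 stands level with the only other true number in the set. That pairing rests on a 1.1-fold lower number from compound 2 to compound 3 (0.02 log units; within the scatter) and it is the measured step closest to the one at hand.

Compound 4 `O=C(Nc1ccc2ccccc2c1)N1CCN(c2nccc(Oc3cc(Cl)cc(Cl)c3)n2)CC1` carries naphthalen-2-yl in place of 2-chlorophenyl on an amide-type nitrogen while the rest of the molecule stays the same.

The larger measured steps, an at least 4.3-fold lower number from compound 1 to compound 2 (0.63 log units; beyond the scatter) and also an at least 4.5-fold lower number from compound 1 to compound 3 (0.65 log units; beyond the scatter) both start from a limit and replace 2,3-dihydro-1H-indol-2-yl on a carbonyl carbon. Compound 4 makes no such change, so they bear on it only weakly.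

Going by the values given here, the one exchange of groups on this nitrogen, a 1.1-fold lower number from compound 2 to compound 3 (0.02 log units; within the scatter) leads to the expectation of no step beyond the scatter, in either direction, although no two-ring group has been measured there. The estimated step is a 1.2-fold lower number from compound 3 to compound 4 (0.09 log units; within the scatter) in size. Compound 4 is expected at 9000 nM with an estimated range from 3500 nM to 28000 nM in this assay by this reasoning.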

Compound 4, half-maximal inhibitory concentration: 46800 nM
Beside the measured number, compound 4's estimate is 5.2-fold (0.72 log units) below it; the whole stated range lies below it.
By their numbers in this assay, from the lowest: compounds 3 and 2 (each within the scatter of the next); then compound 4. At a limit, above all of these: compound 1.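

In this assay, 2-chlorophenyl in place of 4-methylphenyl on the amide-type nitrogen had left the number within the scatter, a 1.1-fold lower number from compound 2 to compound 3 (0.02 log units; within the scatter), but the two-ring naphthalen-2-yl brings a clear loss of inhibition: a 4.3-fold higher number from compound 3 to compound 4 (0.63 log units; beyond the scatter) and a 4.0-fold higher number from compound 2 to compound 4 (0.61 log units; beyond the scatter). This position is therefore not indifferent to the group it carries, and among the three aryl groups shown here, only the one with a second aromatic ring separates from the others. The remaining step, an at least 1.0-fold lower number from compound 1 to compound 4 (0.02 log units; that floor lies within the scatter), cannot be read, since it starts from a limit: the limit of > 50000 nM in this assay, at which 1 of the 4 values shown sits.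

With a single two-ring group on this nitrogen, the compounds shown do not tell whether the loss follows the second ring itself or the way it is attached. Naphthalen-1-yl, unsubstituted phenyl, benzyl or cyclohexyl at this place would help to separate these readings.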